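Removing the fluoro from compound 2's quinazoline-type core: an expectation

This account rests on a few compounds, and the source may have more. Where it says the series, first, only, none or still open, it means among the compounds named here.

The series rests on a shared core with a furanylmethylamino group and a butyl-linked piperazine. Compound 1, `Fc1ccc2nc(NCCCCN3CCN(c4cccc(Cl)c4Cl)CC3)nc(NCc3ccco3)c2c1`, and compound 3, `CN(C)CCCNc1nc(NCc2ccco2)c2ccccc2n1`, were not given a number in a functional assay on MCF7 cells (Homo sapiens) for cytotoxicity, read by MTT assay, with a stated time of 2 days, tested at 10 uM; on this read-out higher numbers stand for more inhibition at the one concentration tested (going by the name of the read-out) and lower numbers for less inhibition: for compound 1 the entry reads "not determined" (no result reported), and for compound 3 it reads "not determined" (no result reported). Within the data shown here, compound 2, `Cc1cccc(N2CCN(CCCCNc3nc(NCc4ccco4)c4cc(F)ccc4n3)CC2)c1C`, is therefore the only member with a measured result; in this assay compound 2 gives 97.7%, a near-complete effect at the single concentration tested, which makes it the sole reference point here.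

Compound 4, `Cc1cccc(N2CCN(CCCCNc3nc(NCc4ccco4)c4ccccc4n3)CC2)c1C`, differs from compound 2 by hydrogen in place of fluoro on an aromatic carbon. Among the measured compounds shown here, no pair of measured compounds shows the effect of such a change, so the expectation rests on compound 2 alone. Because compound 2 already gives 97.7%, the step from compound 2 to compound 4 in this assay is expected to be small and most likely downward, a number 5.7 percentage points lower from compound 2 to compound 4 (within the scatter), staying within the usual scatter. Compound 4 is expected to give about 92% in this assay, within a range from 78% to 100%.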

Compound 4, a percentage reported as inhibition, at one concentration (the size of the read-out at that concentration, not a potency): 95.8%
For compound 4 the middle estimate is 3.8 percentage points below the measured one, and the stated range covers the measured number.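

In this assay, hydrogen in place of fluoro on the aromatic carbon gives a number 1.9 percentage points lower from compound 2 to compound 4 (within the scatter). Among these compounds, this is the first pair of measured compounds that differ in one place, and it shows that, at the one concentration tested, this read-out does not separate fluoro from hydrogen at this position, meta to a fused ring and para to a fused ring. Nothing shown explains this result.

With both compounds so close to the top of the read-out, a single concentration cannot show whether they would differ in potency. As far as these compounds go, it also remains open whether a chloro, methoxy or nitrile group at this position would give a similar reading, and whether a longer chain in place of the butyl chain would do the same.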